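Fluoro for Nitro on Two Related Cores

The source may report more compounds than this note shows. Statements on the series, on what has been measured and on what is new or still open speak of the compounds shown alone.

Compound 1 `O=[N+]([O-])c1ccc(-c2nss/c2=N\c2ccccc2)cc1` and compound 2 `Fc1ccc(-c2nss/c2=N\c2ccccc2)cc1` share one core, while compound 3 `O=[N+]([O-])c1ccc(-c2nssc2=S)cc1` and compound 4 `Fc1ccc(-c2nssc2=S)cc1` share another; the difference between the two cores is not broken down here. In a functional assay on MDA-MB-231 cells (Homo sapiens) for antiproliferative activity, read by MTT assay, with a stated time of 72 h (on this read-out higher numbers stand for weaker inhibition of growth and lower numbers for stronger inhibition of growth), compound 1 gives only a limit, > 10000 nM. In this assay compound 2 likewise gives only a limit, > 10000 nM. The change fluoro in place of nitro on an aromatic carbon therefore gave a step that the two limits leave unreadable from compound 1 to compound 2, because both values sit at the limit of > 10000 nM in this assay, at which 3 of the 3 values shown sit. In this assay compound 3 gives only a limit, > 10000 nM. The change fluoro in place of nitro on an aromatic carbon is the same kind of change, here para to a group of 6 heavy atoms rather than para to a large group. Resting on (the limit of > 10000 nM in this assay, at which 3 of the 3 values shown sit), where every measured value sits, compound 4 is expected to give 15000 nM. The expected step is a step that the limit leaves unreadable from compound 3 to compound 4, an estimate only.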

Compound 4, concentration for 50% growth inhibition: > 10000 nM
Compound 4 was reported as a limit; the forecaster's own chance of this, stated with the estimate: 85%; the middle value lies beyond the limit too.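

No step can be read from compound 3 to compound 4, as both give only a limit: the limit of > 10000 nM in this assay, at which 4 of the 4 values shown sit.

The compounds shown leave open whether fluoro in place of nitro changes growth inhibition at all on either core in this assay.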